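Series notes: sulfanyl substituents on the shared core

The compounds below may be only part of what the source reports. "The series", "measured", "known", "first", "only" and "open" are said of these compounds alone.

Measured so far:
compound 1 `Cc1cc(N2CC[C@@H](C)[C@@H](N(C)c3ncnc4[nH]ccc34)C2)n2ncnc2n1` — 4350 nM
compound 2 `Cc1cc(N2CC[C@@H](C)[C@@H](N(C)c3ncnc4[nH]ccc34)C2)n2nc(SCC3CC3)nc2n1` — 9540 nM
compound 3 `Cc1cc(N2CC[C@@H](C)[C@@H](N(C)c3ncnc4[nH]ccc34)C2)n2nc(SCc3nc4ccccc4[nH]3)nc2n1` — 21200 nM

All three share the core of compound 1 and differ only at one aromatic carbon of the fused ring system. In a functional assay on MGC-803 cells (Homo sapiens) for inhibition, read by MTT assay, with a stated time of 72 h (a lower number here means a stronger inhibitor, a higher number a weaker inhibitor), compound 1 gives the lowest of the three numbers. Compound 2 gives 9540 nM, and a 2.2-fold higher number from compound 1 to compound 2 (0.34 log units; beyond the scatter). Compound 3 gives 21200 nM, and a 4.9-fold higher number from compound 1 to compound 3 (0.69 log units; beyond the scatter). Within the substituted pair, a 2.2-fold higher number from compound 2 to compound 3 (0.35 log units; beyond the scatter).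

Compound 4 `Cc1cc(N2CC[C@@H](C)[C@@H](N(C)c3ncnc4[nH]ccc34)C2)n2nc(SCc3ccc(F)cc3)nc2n1` has not yet been measured. Compared with compound 1: (4-fluorobenzyl)sulfanyl in place of hydrogen on an aromatic carbon

The two measured steps from compound 1 both place a sulfanyl-linked group on this carbon, and both raised the number, the smaller move being from compound 1 to compound 2 and the larger from compound 1 to compound 3. Compound 4 carries a group of the same type, so a step in the same direction is expected in this assay, beyond the scatter but modest, between the two measured steps: the expected step is a 3.0-fold higher number from compound 1 to compound 4 (0.48 log units; beyond the scatter). Compound 4 is therefore estimated at 13000 nM, with a range of 6500 nM to 28000 nM.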

Compound 4, half-maximal inhibitory concentration: 11900 nM
Beside the measured number, compound 4's estimate is 1.1-fold (0.04 log units) above it; the measured number falls inside the stated range.
By their numbers in this assay, from the lowest: compound 1; then compounds 2, 4 and 3 (each within the scatter of the next, the first and the last beyond it).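

In this assay, a third sulfanyl-linked group on this aromatic carbon between two ring nitrogen atoms again moves the number up from that of the unsubstituted core, with a 2.7-fold higher number from compound 1 to compound 4 (0.44 log units; beyond the scatter), so all three substituted compounds lie on the same side of compound 1. What is new is that a 4-fluorophenyl on the saturated chain carbon bound to the sulfur cannot be separated from either earlier group, with a 1.2-fold higher number from compound 2 to compound 4 (0.10 log units; within the scatter) and a 1.8-fold lower number from compound 3 to compound 4 (0.25 log units; within the scatter), even though the two earlier groups do differ beyond the scatter, with a 2.2-fold higher number from compound 2 to compound 3 (0.35 log units; beyond the scatter). Compound 4 therefore has no order against compound 2 or compound 3, and the substituted compounds do not fall into clearly separate levels.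

No measurement on these compounds bears on the reason for the rise over hydrogen. As far as these compounds go, it remains open whether the rise belongs to the sulfur link or to what it carries, which an amine or a plain methyl on the same carbon, or a longer chain between the sulfur and the ring, could help to answer.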